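From Fluoro to Cyano: What Compound 4 Might Show

This account rests on a few compounds, and the source may have more. Where it says the series, first, only, none or still open, it means among the compounds named here.

Compound 3 `O=S(=O)(c1cccc(F)c1)c1cnc2c(F)cccc2c1-c1ccccc1F` holds the second highest of the three numbers recorded so far in an ADME assay on microsomes from liver (Homo sapiens) for metabolic stability, tested at 2.5 uM (on this read-out lower numbers stand for slow clearance and higher numbers for fast clearance), where compound 3 gives 0.21 mL/min. Its nearest neighbour is compound 1 `O=S(=O)(c1cc(F)cc(F)c1)c1cnc2c(F)cccc2c1-c1ccccc1F`, which in this assay gives 0.09 mL/min; the step of a 2.3-fold higher number from compound 1 to compound 3 (0.37 log units; beyond the scatter) is modest yet beyond the scatter, and it comes from hydrogen in place of fluoro on an aromatic carbon. Furthest away stands compound 2 `N#Cc1cccc(S(=O)(=O)c2cnc3c(F)cccc3c2-c2cccc(Cl)c2)c1`, which in this assay gives 1.11 mL/min, the highest number of the three; compound 2 carries a 3-cyanophenyl but differs from compound 3 in a second place as well, so no single step links the two.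

Compound 4 `N#Cc1cccc(S(=O)(=O)c2cnc3c(F)cccc3c2-c2ccccc2F)c1` arises from compound 3 by cyano in place of fluoro on an aromatic carbon. Among the compounds with values here, no measured step covers exactly this exchange. Within the data shown here, the one single step in hand removes a fluoro rather than replacing it with cyano, so it bears on the question only loosely. Among the measured compounds shown here, the only cyano-bearing compound, compound 2, shows the highest number, which the analyst reads as a weak pointer upward. He therefore expects a step of a 2.1-fold higher number from compound 3 to compound 4 (0.33 log units; beyond the scatter), upward and beyond the scatter but well short of the gap to compound 2. His estimate for compound 4 in this assay is 0.45 mL/min, expected to fall between 0.15 mL/min and 1.1 mL/min.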

Compound 4, intrinsic clearance in a liver preparation (reported as CLH), per the amount of preparation that the assay uses: 0.66 mL/min
The estimate for compound 4 lay 1.5-fold (0.17 log units) below the measured number, and the stated range covers the measured number.
By their numbers in this assay, from the lowest: compound 1; then compound 3; then compounds 4 and 2 (each within the scatter of the next).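

In this assay, within the data shown here, turning the 3-fluorophenyl into a 3-cyanophenyl gives a 3.1-fold higher number from compound 3 to compound 4 (0.50 log units; beyond the scatter), the first direct reading of cyano in place of fluoro on this aromatic carbon, and it runs in the same upward direction as the one earlier single step, a 2.3-fold higher number from compound 1 to compound 3 (0.37 log units; beyond the scatter). The change on the sulfonyl sulfur, 3-cyanophenyl in place of 3,5-difluorophenyl, gives a 7.3-fold higher number from compound 1 to compound 4 (0.87 log units; beyond the scatter) and so spans the whole range from the lowest number to the cyano compounds. With the 3-cyanophenyl held constant, 2-fluorophenyl in place of 3-chlorophenyl gives a 1.7-fold lower number from compound 2 to compound 4 (0.23 log units; within the scatter), so this exchange on the other ring does not separate the two compounds on this read-out.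

Nothing among the data accounts for any of these steps. As far as these compounds go, it remains open whether another group on this aromatic carbon, such as methoxy, an amide or a carboxylic acid, would give a number nearer to that of the fluoro compounds or to that of the cyano compounds, and whether the cyano step would keep its direction with a 3-chlorophenyl in place of the 2-fluorophenyl.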